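Stilbene series: amino-acid side chains replaced by a diamine

The source may report more compounds than this note shows. Statements on the series, on what has been measured and on what is new or still open speak of the compounds shown alone.

Measured so far in a functional assay on B16-F10 cells (Mus musculus) for antiproliferative activity, read by CCK-8 assay, with a stated time of 48 h; a lower number here means a stronger inhibitor, a higher number a weaker inhibitor:
- compound 1, `COc1ccc(/C=C\c2cc(OC)c(OC)c(OC)c2)cc1OCc1ccc(CNC(C)(C)C(=O)O)cc1`; in this assay compound 1 is reported only as a limit, > 10000 nM.
- compound 2, `COc1ccc(/C=C\c2cc(OC)c(OC)c(OC)c2)cc1OCc1ccc(CN2CCCC[C@H]2C(=O)O)cc1`; in this assay compound 2 is likewise a limit, > 10000 nM.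
- compound 3, `COc1ccc(/C=C\c2cc(OC)c(OC)c(OC)c2)cc1OCc1ccc(CN2CC(C(=O)O)C2)cc1`; in this assay compound 3 is a limit as well, > 10000 nM.

All three results sit at the same assay limit, so the steps among them are unreadable: a step that the two limits leave unreadable from compound 1 to compound 2, a step that the two limits leave unreadable from compound 1 to compound 3 and a step that the two limits leave unreadable from compound 2 to compound 3. Compound 2 therefore stands nowhere on a numbered scale; it is one of three limits, as the limit of > 10000 nM in this assay, at which 3 of the 3 values shown sit, records, and no ordering among compounds 1, 2 and 3 can be drawn.

The unmeasured compound 4, `COc1ccc(/C=C\c2cc(OC)c(OC)c(OC)c2)cc1OCc1ccc(CNCCN(C)C)cc1`, differs from compound 2 as follows: (2-(dimethylamino)ethyl)amino in place of 2-carboxypiperidin-1-yl on a saturated chain carbon bound to an aromatic carbon. The three measured compounds each carry a carboxy group on the side chain, and all three are limits; compound 4 carries none. Among the compounds with values here, no measured step bears on this change, so its direction and size cannot be read from the series, and the only anchor is the limit of compound 2.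

For compound 4 a value of 3000 nM is estimated, within 300 nM to 30000 nM, which would mean an expected step of an at least 3.3-fold lower number from compound 2 to compound 4 (0.52 log units; beyond the scatter), held with low confidence.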

Compound 4, half-maximal inhibitory concentration: > 10000 nM
Compound 4 ended at the assay's limit (the forecaster's own chance of this, stated with the estimate: 40%); at least 3.3-fold (0.52 log units) between middle value and limit.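

In this assay compound 4 is reported only as a limit, > 10000 nM. Its steps to compound 1, compound 2 and compound 3 cannot be read, and no ordering follows, because every result shown is a limit: the limit of > 10000 nM in this assay, at which 4 of the 4 values shown sit.

The compounds shown leave open whether any side chain on the shared core gives a numbered value in this assay.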